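Swapping Phenyl for Thiophene on a Weak Nucleoside

The source may hold more compounds than are shown below. What is called first, only, known or untested is meant among the compounds shown, and "the series" means these compounds.

Compound 3 `COc1ncnc2c1c(-c1ccccc1)cn2[C@@H]1O[C@H](CO)[C@@H](O)[C@H]1O` is the starting point. In an ADME assay on MRC5 cells (Homo sapiens), read by MTT assay, with a stated time of 72 h (on this read-out lower numbers stand for stronger inhibition and higher numbers for weaker inhibition), compound 3 gives only a limit, > 100000 nM, so its true number is not known. Its closest measured neighbour is compound 1 `COc1ncnc2c1c(I)cn2[C@@H]1O[C@H](CO)[C@@H](O)[C@H]1O`, which in this assay gives 63000 nM; the change from iodo to phenyl is read as an at least 1.5-fold higher number from compound 1 to compound 3 (0.20 log units; that floor lies within the scatter). Compound 2 `COc1nc(N)nc2c1c(-c1ccccc1)cn2[C@@H]1O[C@H](CO)[C@@H](O)[C@H]1O` also gives only a limit in this assay, > 100000 nM. The comparison of the two limits gives a step that the two limits leave unreadable from compound 2 to compound 3.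

Compound 4 `COc1ncnc2c1c(-c1ccsc1)cn2[C@@H]1O[C@H](CO)[C@@H](O)[C@H]1O` differs from compound 3 by thiophen-3-yl in place of phenyl on an aromatic carbon. For the measured compounds named here, no measured step exchanges phenyl for thiophen-3-yl, so nothing directly predicts the size of this move. Compound 3 is itself unresolved because of the limit of > 100000 nM in this assay, at which 2 of the 3 values shown sit. The step is therefore expected to be a number no higher from compound 3 to compound 4 (the limit leaves the size open), with compound 4 most likely sitting at the same limit. Compound 4 is estimated at 100000 nM, within 50000 nM to 300000 nM.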

Compound 4, half-maximal inhibitory concentration: 75300 nM
Compound 4: middle estimate off by 1.3-fold (0.12 log units), on the high side, and the stated range covers the measured number.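

At this aromatic carbon, a ring group need not end in a limit in this assay: thiophen-3-yl gives a readable number where phenyl gave only a limit, with an at least 1.3-fold lower number from compound 3 to compound 4 (0.12 log units; that floor lies within the scatter). Set against iodo, the thiophen-3-yl group makes no difference that stands clear of the usual scatter, with a 1.2-fold higher number from compound 1 to compound 4 (0.08 log units; within the scatter). The phenyl swap can therefore be given only as a floor, and its true size stays unknown: the limit of > 100000 nM in this assay, at which 2 of the 4 values shown sit.

On these data alone, what a carboxylic acid or an amine at this aromatic carbon would give stays open. Also open, as far as these compounds go, is whether the amino group of compound 2 would change the number in a compound that carries thiophen-3-yl, since the step between compound 2 and compound 3 cannot be read.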